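A few compounds are considered here, and "the series" means these few. Any claim that something is new, unique, unknown or untested is made for them only; others in the source may bear on it.

Compound 2 `COc1ccc(CN(C(=O)CSC(=S)N2CCN(C(=O)OC(C)(C)C)CC2)c2cc(OC)c(OC)c(OC)c2)cc1` gives 620 nM in a functional assay on HCT-116 cells (Homo sapiens) for inhibition, read by CCK-8 assay, with a stated time of 48 h (a lower number here means a stronger inhibitor, a higher number a weaker inhibitor), the lowest of the two numbers in hand; compound 1 `COc1ccc(CN(C(=O)CSC(=S)N2CCN(C)CC2)c2cc(OC)c(OC)c(OC)c2)cc1` gives 2640 nM, and the step of a 4.3-fold lower number from compound 1 to compound 2 (0.63 log units; beyond the scatter) came from a change at the amine nitrogen in a ring. Compound 3 `COc1ccc(CN(C(=O)CSC(=S)N2CCN(C(=O)OC(C)(C)C)CC2)c2cc(OC)c(OC)c(OC)c2)cc1N` differs from compound 2 by amino in place of hydrogen on an aromatic carbon. Among the compounds with values here, no measured step touches that position, so the one known step does not bear directly on this change. The step of a 1.3-fold higher number from compound 2 to compound 3 (0.11 log units; within the scatter) expected here is thought to stay within the scatter. Compound 3 is estimated at 800 nM, within a range from 250 nM to 2500 nM.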

Compound 3, half-maximal inhibitory concentration: 352 nM
For compound 3 the middle estimate is 2.3-fold (0.36 log units) above the measured one; low and high end bracket the measured number.
By their numbers in this assay, from the lowest: compounds 3 and 2 (each within the scatter of the next); then compound 1.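

In this assay the change from 4-methoxybenzyl to 3-amino-4-methoxybenzyl brings a 1.8-fold lower number from compound 2 to compound 3 (0.25 log units; within the scatter) and so no difference that can be told from the scatter. Within the data shown here, this is the first reading at this aromatic carbon, ortho to a methoxy group, and it shows that the amino group is tolerated there. Nothing in hand accounts for this result.

From the compounds shown here alone, whether a hydroxyl, a nitro group or an acetamide on the same carbon would read alike remains open. So does whether the amino group would behave the same with methyl in place of tert-butoxycarbonyl on the ring nitrogen.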